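The source may hold more compounds than are shown below. What is called first, only, known or untested is meant among the compounds shown, and "the series" means these compounds.

Measured compounds:
compound 1 `CCC(C)Sc1nc(N)nc2c1ncn2[C@@H]1O[C@H](CO)[C@@H](O)[C@H]1O` — 63100 nM in an assay on isolated protein for binding affinity to Equilibrative nucleoside transporter 1 (Homo sapiens); on this read-out higher numbers stand for weaker inhibition and lower numbers for stronger inhibition
compound 2 `CC(C)Sc1nc(N)nc2c1ncn2[C@@H]1O[C@H](CO)[C@@H](O)[C@H]1O` — 191000 nM in this assay

Both compounds share the same core and differ only in the small alkyl group attached to the sulfur. Among the compounds with values here, compound 2 has the highest number of the two in this assay; the only other measured compound, compound 1, shows a lower number, and the step of a 3.0-fold higher number from compound 1 to compound 2 (0.48 log units; beyond the scatter) lies beyond the usual scatter.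

Compound 3 `Cc1cccc(CSc2nc(N)nc3c2ncn3[C@@H]2O[C@H](CO)[C@@H](O)[C@H]2O)n1` is not yet measured. It is derived from compound 2 by the change ((6-methylpyridin-2-yl)methyl in place of isopropyl on a sulfur), so the sulfur now carries a larger group containing an aromatic ring in place of a short branched chain.

Within the data shown here, only one measured step bears on this, and only loosely: going from the larger sec-butyl to the smaller isopropyl gave a 3.0-fold higher number from compound 1 to compound 2 (0.48 log units; beyond the scatter), so a larger group on the sulfur went with a lower number. The change to compound 3 adds far more than a single methyl, and it introduces a ring and an acceptor, which nothing measured here covers. A lower number for compound 3 is therefore expected, of uncertain size; the expected step is a 64-fold lower number from compound 2 to compound 3 (1.80 log units; beyond the scatter). The estimate for compound 3 is 3000 nM, within a range from 200 nM to 40000 nM.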

Compound 3, half-maximal inhibitory concentration: 11500000 nM
Compound 3: the middle estimate sits 3800-fold (3.58 log units) below what was measured, and the stated range ends below it.
By their numbers in this assay, from the lowest: compound 1; then compound 2; then compound 3.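

In this assay, (6-methylpyridin-2-yl)methyl on the sulfur gives a 60-fold higher number from compound 2 to compound 3 (1.78 log units; beyond the scatter) when it replaces isopropyl, and a 180-fold higher number from compound 1 to compound 3 (2.26 log units; beyond the scatter) when it replaces sec-butyl. Compound 3 therefore goes against the hint from compound 1 and compound 2 that a larger group on this sulfur brings a lower number: the bigger group, which carries an aromatic ring, has the highest number of the three and so the weakest inhibition. This position is thus not governed by group size alone, and this change moves the number much further than the modest step between the two short chains did. No other data on these compounds speak to why the number rose.

Compound 3 brings in the ring, its nitrogen, its methyl and the linking carbon all at once, so the compounds shown cannot tell which of these parts matters. Also open, on these data alone, is how a plain benzyl group, a longer chain such as n-pentyl, or a chain ending in an amine would read on this sulfur, and whether any of them would bring the number below that of compound 1.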